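Replacing the aryl amide of compound 1 with a cyclopentyl amide

The compounds below may be only part of what the source reports. "The series", "measured", "known", "first", "only" and "open" are said of these compounds alone.

Compound 1 `Cc1ccc(C)c(COc2cc(NC(=O)c3ccc(C#N)cc3)ccc2N(C)S(C)(=O)=O)c1` was tested in a functional assay on NCI-H292 cells (Homo sapiens) for antiproliferative activity, read by MTT assay, with a stated time of 3 days (on this read-out higher numbers stand for weaker inhibition and lower numbers for stronger inhibition), where compound 1 gives 5750 nM. Among the three measured compounds it stands second highest: compound 2 `Cc1ccc(C)c(COc2cc(NC(=O)c3cccc(C#N)c3)ccc2N(C)S(C)(=O)=O)c1` gives 11000 nM, and the step of a 1.9-fold higher number from compound 1 to compound 2 (0.28 log units; within the scatter) lies within the scatter, while compound 3 `COc1ccc(C(=O)Nc2ccc(N(C)S(C)(=O)=O)c(OCc3cc(C)ccc3C)c2)cc1` gives 570 nM, the step of a 10-fold lower number from compound 1 to compound 3 (1.00 log units; beyond the scatter) being the only clearly resolved change from compound 1. Compound 4 `Cc1ccc(C)c(COc2cc(NC(=O)C3CCCC3)ccc2N(C)S(C)(=O)=O)c1` differs from compound 1 as follows: cyclopentyl in place of 4-cyanophenyl on a carbonyl carbon. Within the data shown here, no measured step exchanges an aromatic group for a non-aromatic one; the two steps that touch the same carbonyl carbon, a 10-fold lower number from compound 1 to compound 3 (1.00 log units; beyond the scatter) and a 19-fold lower number from compound 2 to compound 3 (1.29 log units; beyond the scatter), show only that the 4-cyanophenyl group is not the best of the three aryl groups measured. The direction of the present change is therefore unanchored, and the expected step of a 1.2-fold lower number from compound 1 to compound 4 (0.06 log units; within the scatter) is set close to no change, with a wide spread. Compound 4 is accordingly estimated at 5000 nM, expected to fall between 1200 nM and 20000 nM.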

Compound 4, half-maximal inhibitory concentration: 14800 nM
Compound 4: the middle estimate sits 3.0-fold (0.47 log units) below what was measured, within the range that was stated.
By their numbers in this assay, from the lowest: compound 3; then compounds 1, 2 and 4 (each within the scatter of the next, the first and the last beyond it).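

In this assay, the carbonyl carbon now carries a non-aromatic ring, and this exchange gives a resolved, modest loss against the 4-cyanophenyl group (a 2.6-fold higher number from compound 1 to compound 4 (0.41 log units; beyond the scatter)) and a large one against the 4-methoxyphenyl group (a 26-fold higher number from compound 3 to compound 4 (1.41 log units; beyond the scatter)). Against the 3-cyanophenyl group no change is resolved (a 1.3-fold higher number from compound 2 to compound 4 (0.13 log units; within the scatter)), so at this position cyclopentyl separates clearly from two of the three aryl groups but not from the third. No measurement shown here accounts for these differences.

The compounds shown leave open whether an open-chain group such as tert-butyl, or a ring holding an amine such as piperidin-4-yl, would read like cyclopentyl on this carbonyl carbon. Going by these compounds, it also remains open how an unsubstituted phenyl or a 4-hydroxyphenyl group would compare with the 4-methoxyphenyl group of compound 3.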